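Aryl sulfonates: a methylphenyl to chlorophenyl swap

This account rests on a few compounds, and the source may have more. Where it says the series, first, only, none or still open, it means among the compounds named here.

Measured compounds and their results:
- compound 1, `CN1CCN(c2ccc(S(=O)(=O)Oc3cc(Cl)c(Cl)cc3Cl)cc2)C1=O`: 420 nM
- compound 2, `Cc1cccc(OS(=O)(=O)c2ccc(N3CCN(C)C3=O)cc2)c1`: 2300 nM
- compound 3, `COc1cc(OS(=O)(=O)c2ccc(N3CCN(C)C3=O)cc2)cc(OC)c1OC`: 54 nM

Three sulfonate esters sharing one core have been tested in a functional assay on M21 cells (Homo sapiens) for antiproliferative activity, read by sulforhodamine B assay, with a stated time of 48 h; a lower number here means a stronger inhibitor, a higher number a weaker inhibitor. Compound 2 stands at the high end of the three: its number is the largest, with compound 1 nearer to it and compound 3 furthest from it, and both of those gaps lie beyond the usual scatter of the measurement. Compound 3 thus gives the lowest number of the set, and compound 1 sits in between.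

The next compound, compound 4 `CN1CCN(c2ccc(S(=O)(=O)Oc3ccc(Cl)cc3)cc2)C1=O`, has not been measured yet. It differs from compound 2 in one place: 4-chlorophenyl in place of 3-methylphenyl on an oxygen. Because compound 1 gives 420 nM as the other chlorine-bearing ester, the chlorophenyl ester is expected to come in somewhat lower than compound 2, though compound 1 carries three chlorines and compound 4 only one, so the step is expected to be modest. The estimated step of a 2.3-fold lower number from compound 2 to compound 4 (0.36 log units; beyond the scatter) is expected to be a moderate decrease, at the edge of the scatter. Compound 4 is expected to give about 1000 nM, within a range from 350 nM to 3000 nM.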

Compound 4, half-maximal inhibitory concentration: 43000 nM
Compound 4: middle estimate off by 43-fold (1.63 log units), on the low side; the whole stated range lies below it.
By their numbers in this assay, from the lowest: compound 3; then compound 1; then compound 2; then compound 4.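

In this assay, the aryl group on the oxygen whose other neighbour is the sulfonyl sulfur proves highly sensitive to a swap that leaves the counted features unchanged: 4-chlorophenyl in place of 3-methylphenyl gives a 19-fold higher number from compound 2 to compound 4 (1.27 log units; beyond the scatter), though both groups have the same number of heavy atoms, the same count of hydrogen-bond donors and acceptors, and no net charge. The earlier compounds shown here did not show that a chlorine-bearing ester could sit at the top of the series, and a chlorine alone does not bring a low number here, as compound 1 gives 420 nM while compound 4 gives 43000 nM. Nothing available explains why this swap raises the number so sharply.

Going by these compounds, whether the rise follows the chlorine itself or its place on the ring stays open, as this swap changes both at once, and a 3-chlorophenyl or 4-methylphenyl ester would separate the two. On these data alone, how an amine or a carboxylic acid on this aryl ring would read in this assay also remains open.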